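The compounds below may be only part of what the source reports. "The series", "measured", "known", "first", "only" and "open" are said of these compounds alone.

Compound 3 `CC(C)(CCCC/C=C(\c1ccccc1)c1cccnc1)C(=O)O` gives 45 nM in an assay (Equus caballus) for inhibition of Thromboxane-A synthase (Homo sapiens), using microsomes (on this read-out lower numbers stand for stronger inhibition and higher numbers for weaker inhibition), which places it second highest of the three numbers; compound 1 `CC(C)(O)C(CCC/C=C(\c1ccccc1)c1cccnc1)C(=O)O` gives 42 nM and compound 2 `O=C(O)C(CCC/C=C(\c1ccccc1)c1cccnc1)C1(O)CCCC1` gives 65 nM, both within the scatter of compound 3. Compound 4 `C=C(C)C(CCC/C=C(\c1ccccc1)c1cccnc1)C(=O)O` differs from compound 3 by 1-carboxy-2-methylprop-2-en-1-yl in place of 2-carboxy-2-methylpropyl on a saturated chain carbon, three bonds along the chain from a double-bonded chain carbon. The steps around the carboxylic acid end were small: a 1.1-fold higher number from compound 1 to compound 3 (0.03 log units; within the scatter) and a 1.5-fold higher number from compound 1 to compound 2 (0.19 log units; within the scatter). Since varying this end of the chain among compounds 1, 2 and 3 has moved nothing beyond the scatter, a step of similar size is expected here, with no clear direction, a 1.1-fold higher number from compound 3 to compound 4 (0.05 log units; within the scatter). Compound 4 is therefore expected to give about 50 nM, between 20 nM and 130 nM.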

Compound 4, half-maximal inhibitory concentration: 28 nM
Estimate against measurement, compound 4: 1.8-fold (0.25 log units) above; the range from low to high includes it.
By their numbers in this assay, from the lowest: compounds 4, 1, 3 and 2 (each within the scatter of the next, the first and the last beyond it).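

The 1-methylethenyl group on this saturated chain carbon gives a 1.5-fold lower number from compound 1 to compound 4 (0.18 log units; within the scatter) in place of 1-hydroxy-1-methylethyl, and the full side-chain change from 2-carboxy-2-methylpropyl gives a 1.6-fold lower number from compound 3 to compound 4 (0.21 log units; within the scatter). Among these compounds, in place of 1-hydroxycyclopentyl it gives a 2.3-fold lower number from compound 2 to compound 4 (0.37 log units; beyond the scatter), the first step at this end of the chain to pass the scatter, though a modest one that holds against only one neighbour. No supporting data offer an explanation for this step. The compounds shown leave open how an amine or an ethyl group on this carbon would compare.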